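Working notes: from compound 1 to compound 3

A few compounds are considered here, and "the series" means these few. Any claim that something is new, unique, unknown or untested is made for them only; others in the source may bear on it.

Values from a functional assay on HeLa cells (Homo sapiens) for cytotoxicity, read by MTT assay, with a stated time of 24 h (a higher number here means a weaker inhibitor, a lower number a stronger inhibitor), follow
- compound 1 `CCCCCCCCCCn1cc(-c2nc3ccccc3cc2C)nn1` gives 28.2 ug/mL
- compound 2 `Cc1cc2ccccc2nc1-c1cn(-c2ccc(F)cc2)nn1` gives > 100 ug/mL as a limit of the assay

For the measured compounds named here, compound 1 holds the only actual number (28.2 ug/mL). The value for compound 2 (> 100 ug/mL) is a limit and not a number. Compound 3 `CCCCCCCCCCn1cc(-c2nc3ccccc3cc2CCCCC)nn1` carries butyl in place of hydrogen on a saturated chain carbon bound to an aromatic carbon. Going by the values given here, no measured step bears on this change, so in this assay no shift beyond the scatter is expected, and no direction is favoured. The estimated step runs a 1.1-fold higher number from compound 1 to compound 3 (0.03 log units; within the scatter) on this reading. Compound 3 is estimated at 30 ug/mL within an expected range (12 ug/mL to 80 ug/mL).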

Compound 3, half-maximal inhibitory concentration: > 100 ug/mL
Compound 3: only a limit was reported (the forecaster's own chance of this, stated with the estimate: 12%); at least 3.3-fold (0.52 log units) between middle value and limit.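

In this assay, the saturated chain carbon bound to an aromatic carbon proves sensitive to substitution: butyl in place of hydrogen there gives an at least 3.5-fold higher number from compound 1 to compound 3 (0.54 log units; beyond the scatter), the first step read at this position. Compound 3 gives > 100 ug/mL, which is a limit of the assay and not a number. The step therefore fixes a direction but only a minimum size, because it ends at the assay limit: the limit of > 100 ug/mL in this assay, at which 2 of the 3 values shown sit.

The compounds shown leave open how an ethyl chain or an amine at this place would read. They also leave open whether any change here yields a lower number than that of compound 1.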